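Removing Two Substituents From the Amide Aryl Ring

The compounds below may be only part of what the source reports. "The series", "measured", "known", "first", "only" and "open" are said of these compounds alone.

Measured so far in a functional assay on SF-295 cells (Homo sapiens) for inhibition, read by sulforhodamine B assay, with a stated time of 48 h; a higher number here means a weaker inhibitor of growth, a lower number a stronger inhibitor of growth:
compound 1, `COc1cc(-c2nn(-c3cccc(NC(=O)c4cccc(C(F)(F)F)c4)c3)cc2-c2ccncc2)ccc1Cl`, gives 3000 nM
compound 2, `COc1cc(-c2nn(-c3cccc(NC(=O)Nc4ccc(Cl)c(Cl)c4)c3)cc2-c2ccncc2)ccc1Cl`, gives 2530 nM
compound 3, `COc1cc(-c2nn(-c3cccc(NC(=O)c4ccc(Cl)c(C(F)(F)F)c4)c3)cc2-c2ccncc2)ccc1Cl`, gives 17300 nM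

All three share one core and differ only in the group attached to the carbonyl of the amide. In this assay compound 3 stands at the highest number of the three, that is, it is the weakest grower-inhibitor of the set. Compound 1 and compound 2 lie close to each other: a 1.2-fold lower number from compound 1 to compound 2 (0.07 log units; within the scatter). Compound 3 is set apart from both: a 5.8-fold higher number from compound 1 to compound 3 (0.76 log units; beyond the scatter), and a 6.8-fold higher number from compound 2 to compound 3 (0.83 log units; beyond the scatter).

Compound 4, `COc1cc(-c2nn(-c3cccc(NC(=O)c4ccccc4)c3)cc2-c2ccncc2)ccc1Cl`, has not yet been measured. It differs from compound 3 in one place: phenyl in place of 4-chloro-3-(trifluoromethyl)phenyl on a carbonyl carbon. For the measured compounds named here, of the measured steps, the one from compound 1 to compound 3 bears most directly, since compound 4 reverses that chloro addition and additionally loses the trifluoromethyl. Going by the values given here, removing the trifluoromethyl alone has no measured counterpart here, so the expectation rests on compound 1. Because a 5.8-fold higher number from compound 1 to compound 3 (0.76 log units; beyond the scatter), a lower number for compound 4 than for compound 3 is expected, roughly undoing that step: the expected change is a 4.9-fold lower number from compound 3 to compound 4 (0.69 log units; beyond the scatter). Compound 4 is therefore estimated to give 3500 nM in this assay, with a range from 1200 nM to 10000 nM.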

Compound 4, concentration for total growth inhibition: 2260 nM
Compound 4: the middle estimate sits 1.5-fold (0.19 log units) above what was measured, and the stated range covers the measured number.
By their numbers in this assay, from the lowest: compounds 4, 2 and 1 (each within the scatter of the next); then compound 3.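

For the compounds shown here, compound 4 carries a plain phenyl on the carbonyl carbon, and it shows that neither substituent on this ring is required for growth inhibition at this level in this assay: replacing the trifluoromethyl with hydrogen gives a 1.3-fold lower number from compound 1 to compound 4 (0.12 log units; within the scatter), a single change that the earlier compounds did not isolate. Phenyl in place of (3,4-dichlorophenyl)amino gives a 1.1-fold lower number from compound 2 to compound 4 (0.05 log units; within the scatter), while phenyl in place of 4-chloro-3-(trifluoromethyl)phenyl gives a 7.7-fold lower number from compound 3 to compound 4 (0.88 log units; beyond the scatter), so among these four compounds only the ring carrying both chloro and trifluoromethyl stands apart. Nothing available here bears on the reason for that difference.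

The compounds shown leave open whether a phenyl carrying a 4-chloro group alone, without the trifluoromethyl, would read like the weak ring or like plain phenyl. They also leave open how an amine or a carboxylic acid on this ring, or a longer chain in place of the phenyl, would behave in this assay.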